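The compounds below may be only part of what the source reports. "The series", "measured", "known", "first", "only" and "open" are said of these compounds alone.

Working notes on the series. Compound 1 `CN(C)CCn1cnnc1-c1cc(Oc2ccc(NC(=O)N/N=C/c3ccc(O)c(F)c3)cc2F)ccn1` gives 13400 nM in a functional assay on A549 cells (Homo sapiens) for cytotoxicity, read by MTT assay, with a stated time of 72 h; on this read-out higher numbers stand for weaker inhibition and lower numbers for stronger inhibition. Compound 2 `CN(C)CCn1cnnc1-c1cc(Oc2ccc(NC(=O)N/N=C/c3cc(Br)c(O)c(Br)c3)cc2F)ccn1` is reported in this assay only as a limit, > 100000 nM, and so stands at the weak end of the numbers shown (the limit of > 100000 nM in this assay, at which 1 of the 3 values shown sits). Compound 3 `Cn1cnnc1-c1cc(Oc2ccc(NC(=O)N/N=C/c3ccccc3)cc2F)ccn1`, which carries a phenyl on the carbon with a double bond to nitrogen, gives 7560 nM in this assay.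

Going by the values given here, the single measured step is an at least 7.4-fold higher number from compound 1 to compound 2 (0.87 log units; beyond the scatter), where 3,5-dibromo-4-hydroxyphenyl replaced 3-fluoro-4-hydroxyphenyl.

Compound 4 `CN(C)CCn1cnnc1-c1cc(Oc2ccc(NC(=O)N/N=C/c3ccccc3)cc2F)ccn1` is not yet measured. Against compound 2 the change is phenyl in place of 3,5-dibromo-4-hydroxyphenyl on a carbon with a double bond to nitrogen. The step from compound 1 to compound 2 bears on it, since it runs the other way, from a substituted hydroxyphenyl back to a bare ring: compound 1 with 3-fluoro-4-hydroxyphenyl gives 13400 nM, and compound 3 with plain phenyl gives 7560 nM. Therefore the expected step is an at least 11-fold lower number from compound 2 to compound 4 (1.04 log units; beyond the scatter). Compound 4 is expected to give about 9000 nM in this assay, in the range 3000 nM to 30000 nM.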

Compound 4, half-maximal inhibitory concentration: 1860 nM
Beside the measured number, compound 4's estimate is 4.8-fold (0.68 log units) above it; the measured number lies below the stated range.
By their numbers in this assay, from the lowest: compound 4; then compounds 3 and 1 (each within the scatter of the next). At a limit, above all of these: compound 2.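

With the (dimethylamino)methyl chain kept, plain phenyl on the carbon with a double bond to nitrogen gives a lower number in this assay than either substituted hydroxyphenyl, with a 7.2-fold lower number from compound 1 to compound 4 (0.86 log units; beyond the scatter) and an at least 53-fold lower number from compound 2 to compound 4 (1.73 log units; beyond the scatter). Going by these compounds alone, the same chain also matters with the phenyl ring in place, with a 4.1-fold lower number from compound 3 to compound 4 (0.61 log units; beyond the scatter), so this change in the chain is now seen to count in its own right, a step the earlier compounds did not offer. Compound 2 is known here only as a limit: the limit of > 100000 nM in this assay, at which 1 of the 4 values shown sits.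

The compounds shown hold no plain 4-hydroxyphenyl and no 3-fluorophenyl on that carbon, so the separate shares of the hydroxyl and the halogens stay open. Also open, from the compounds shown here alone, is whether a morpholine or a longer amine chain would follow the (dimethylamino)methyl step.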